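Triazole aryl exchange on two related tricyclic cores

The source may hold more compounds than are shown below. What is called first, only, known or untested is meant among the compounds shown, and "the series" means these compounds.

Measured compounds:
Compound 1, `Cc1c(O)ccc2c1[C@H](Cn1cc(-c3ccc(F)cc3)nn1)[C@@]13CC(=O)[C@@](C)(CC[C@@H]21)C3`, gives > 20000 nM in a functional assay on A549 cells (Homo sapiens) for cytotoxicity, read by MTT assay, with a stated time of 4 days; on this read-out higher numbers stand for weaker inhibition and lower numbers for stronger inhibition; this value is a limit of the assay.
Compound 2, `C=C1C(=O)[C@]23C[C@@]1(O)CC[C@H]2c1ccc(O)c(C)c1[C@@H]3Cn1cc(-c2ccccn2)nn1`, gives 1570 nM in this assay.
Compound 3, `Cc1c(O)ccc2c1[C@H](Cn1cc(-c3ccccn3)nn1)[C@@]13CC(=O)[C@@](C)(CC[C@@H]21)C3`, gives > 20000 nM in this assay; this value is a limit of the assay.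

Compounds 1 and 3 share one core and differ by a single change, (4-fluorophenyl in place of pyridin-2-yl on an aromatic carbon). The step between them, a step that the two limits leave unreadable from compound 3 to compound 1, cannot be read because of the limit of > 20000 nM in this assay, at which 2 of the 3 values shown sit. Compound 2 sits on a different core, and the difference between the two cores is not broken down here. Among the compounds with values here, compound 2 is the only compound with a number in this assay.

Compound 4, `C=C1C(=O)[C@]23C[C@@]1(O)CC[C@H]2c1ccc(O)c(C)c1[C@@H]3Cn1cc(-c2ccc(F)cc2)nn1`, has not yet been measured. It differs from compound 2 by 4-fluorophenyl in place of pyridin-2-yl on an aromatic carbon, the same change that turns compound 3 into compound 1, the place being described in the same words on both cores. Within the data shown here, that earlier step gave no readable size, so the expectation for compound 4 rests on compound 2 alone, whose 1570 nM is the only number available. Compound 4 is expected to give about 2200 nM in this assay, with a range from 600 nM to 9000 nM. This estimate means an expected step of a 1.4-fold higher number from compound 2 to compound 4 (0.15 log units; within the scatter), held close to no change since the same change on the other core left both compounds at the assay limit.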

Compound 4, half-maximal inhibitory concentration: 940 nM
Estimate against measurement, compound 4: 2.3-fold (0.37 log units) above, and the stated range covers the measured number.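

In this assay, putting 4-fluorophenyl in place of pyridin-2-yl on the core of compound 2 gives a 1.7-fold lower number from compound 2 to compound 4 (0.22 log units; within the scatter), so the two compounds cannot be told apart on this read-out. Whether the change behaves alike on both cores cannot be said, because the step from compound 3 to compound 1 cannot be read: the limit of > 20000 nM in this assay, at which 2 of the 4 values shown sit. Nothing shown separates the two aromatic groups on either core, yet a single readable pair gives no ground for a rule that carries across the series.

The compounds shown leave open how the read-out would respond on the core of compound 2 to a group of a different kind at this place on the five-membered aromatic ring, such as morpholine, a carboxylic acid or a longer alkyl chain. They also leave open which of the features that separate the two cores matters to the read-out; no compound shown changes one of those features alone.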